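The compounds below may be only part of what the source reports. "The series", "measured", "known", "first", "only" and "open" are said of these compounds alone.

Measured in an assay on cells for displacement of a labelled ligand from corticotropin-releasing factor receptor 1 (Homo sapiens), with a stated time of 100 min; a higher number here means a weaker inhibitor, a lower number a stronger inhibitor:
compound 1 `CCCN(Cc1ccccc1)Cc1c(C(F)(F)F)nc2n(-c3c(C)cc(C)cc3C)c(Cl)cn12` gives 170 nM
compound 2 `Cc1cc(C)c(-n2c(Cl)cn3c(CN4CCC(c5ccccc5)C4)c(C(F)(F)F)nc23)c(C)c1` gives 610 nM

Among the compounds with values here, on these two numbers compound 2 stands highest; its only neighbour is compound 1, and the step of a 3.6-fold higher number from compound 1 to compound 2 (0.55 log units; beyond the scatter) marks the move to the 3-phenylpyrrolidin-1-yl group as a modest weakening. Compound 3 `Cc1cc(C)c(-n2c(Cl)cn3c(CN4CCCC(C)C4)c(C(F)(F)F)nc23)c(C)c1` keeps the core of compound 2 and differs by 3-methylpiperidin-1-yl in place of 3-phenylpyrrolidin-1-yl on a saturated chain carbon bound to an aromatic carbon. Within the data shown here, no measured step bears directly on this change: the one step known, a 3.6-fold higher number from compound 1 to compound 2 (0.55 log units; beyond the scatter), compares two groups that both carry a phenyl ring, whereas the entering 3-methylpiperidin-1-yl group carries none. The direction of the change is therefore not settled by the data. Compound 3 is expected to give a somewhat higher number, a step of about a 2.0-fold higher number from compound 2 to compound 3 (0.29 log units; within the scatter), with wide uncertainty. The estimate for compound 3 in this assay is 1200 nM, within a range of 300 nM to 5000 nM.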

Compound 3, inhibition constant: 5800 nM
For compound 3 the middle estimate is 4.8-fold (0.68 log units) below the measured one, and the stated range ends below it.
By their numbers in this assay, from the lowest: compound 1; then compound 2; then compound 3.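

In this assay, within the data shown here, 3-methylpiperidin-1-yl is the first amine at this saturated chain carbon without a phenyl ring, and replacing 3-phenylpyrrolidin-1-yl with it gives a 9.5-fold higher number from compound 2 to compound 3 (0.98 log units; beyond the scatter). Replacing benzyl(propyl)amino with the same group gives a 34-fold higher number from compound 1 to compound 3 (1.53 log units; beyond the scatter), so the three amines now spread widely in their numbers, and the choice of amine at this place matters far more than the first step alone showed. No measurement on hand accounts for the size of these steps.

Going by these compounds, the step from compound 2 to compound 3 changes the ring size and exchanges phenyl for methyl at once, so the share of each remains open. A 3-phenylpiperidin-1-yl or a 3-methylpyrrolidin-1-yl group at this place would separate the two changes.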